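From Thiophen-2-yl to Thiophen-3-yl: An Expected Cytotoxicity Step

The source may hold more compounds than are shown below. What is called first, only, known or untested is meant among the compounds shown, and "the series" means these compounds.

Of the compounds shown here, two built on the same core have been tested in an ADME assay on HEK293 cells (Homo sapiens) for cytotoxicity, read by CCK-8 assay and cell counting, with a stated time of 2 days; on this read-out lower numbers stand for stronger inhibition and higher numbers for weaker inhibition. Compound 1 `Oc1cccc(-c2cc(-c3ccc(Cl)cc3)nc(-c3cccs3)c2)c1` gives 11800 nM in this assay, and compound 2 `Oc1ccc(-c2cc(-c3ccc(Cl)cc3)nc(-c3cccs3)c2)cc1` gives 4520 nM. Of these two numbers compound 1 stands highest, so it is the weaker of the two at reducing cell viability. Among the compounds with values here, the single measured step is a 2.6-fold lower number from compound 1 to compound 2 (0.42 log units; beyond the scatter), and it concerns only the hydroxyphenyl group.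

Compound 3 `Oc1cccc(-c2cc(-c3ccc(Cl)cc3)nc(-c3ccsc3)c2)c1` is still to be measured. It differs from compound 1 in one place: thiophen-3-yl in place of thiophen-2-yl on an aromatic carbon. Within the data shown here, no measured pair in this set changes the thiophenyl group, so the known step between compound 1 and compound 2 does not bear on this change. With nothing to indicate a direction, the expected step in this assay is no change at the digits printed from compound 1 to compound 3 (within the scatter), meaning none beyond the usual scatter. Compound 3 is therefore estimated at 11800 nM, with a plausible range from 5000 nM to 28000 nM.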

Compound 3, half-maximal inhibitory concentration: 11200 nM
Compound 3: the middle estimate sits 1.1-fold (0.02 log units) above what was measured, and the stated range covers the measured number.
By their numbers in this assay, from the lowest: compound 2; then compounds 3 and 1 (each within the scatter of the next).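

In this assay, thiophen-3-yl in place of thiophen-2-yl, on the aromatic carbon next to the ring nitrogen, gives a 1.1-fold lower number from compound 1 to compound 3 (0.02 log units; within the scatter). Within the data shown here, the earlier pair spoke only of the hydroxyphenyl group, with a 2.6-fold lower number from compound 1 to compound 2 (0.42 log units; beyond the scatter), whereas this pair gives the first reading at the thiophenyl position: the two groups have the same atoms joined differently, and on the core of compound 1 this assay does not tell them apart. Nothing available here accounts for this close agreement between the two thiophenyl groups.

As far as these compounds go, the result covers a single pair, so it remains open whether thiophen-3-yl and thiophen-2-yl would also read alike on the core of compound 2, which carries the 4-hydroxyphenyl group. From the compounds shown here alone, it is equally open whether this position would tolerate a group that differs more from thiophenyl, such as furan-2-yl, an amine or a longer alkyl chain, without a step beyond the scatter.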